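The source may report more compounds than this note shows. Statements on the series, on what has been measured and on what is new or still open speak of the compounds shown alone.

Going by the values given here, compound 3 `C=CC1=C(C(=O)NCc2ccc(C)cc2)C(c2ccc(OC)c(OC)c2)OC1` is one of three compounds so far measured in a functional assay on SW480 cells (Homo sapiens) for cytotoxicity, read by MTT assay, with a stated time of 24 h; on this read-out lower numbers stand for stronger inhibition and higher numbers for weaker inhibition. In this assay compound 3 gives > 100000 nM, which is a limit of the assay and not a number. Compound 1 `C=CC1=C(C(=O)NCCC)C(c2ccc(OC)c(OC)c2)OC1` likewise gives > 100000 nM, again a limit. Compound 2 `C=CC1=C(C(=O)NCc2ccc(C)cc2)C(c2ccc(OC)cc2)OC1` gives 31700 nM, a genuine value. The step of an at least 3.1-fold higher number from compound 2 to compound 3 (0.49 log units; beyond the scatter) can thus be read, whereas the step that the two limits leave unreadable from compound 1 to compound 3 cannot, because both compounds sit at the limit of > 100000 nM in this assay, at which 2 of the 3 values shown sit.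

Compound 4 `C=CC1=C(C(=O)Nc2ccccc2)C(c2ccc(OC)c(OC)c2)OC1` differs from compound 3 by phenyl in place of 4-methylbenzyl on an amide-type nitrogen. Among the compounds with values here, of the measured steps only the one from compound 1 to compound 3 touches the same position, and its size is not readable; the change from compound 2 to compound 3 concerns a different part of the molecule and offers no guide here. Within the data shown here, compound 3 itself stands at the limit, and no measured step points toward a lower number after this change. Compound 4 is therefore expected near 100000 nM, between 30000 nM and 300000 nM. The step of a number no higher from compound 3 to compound 4 (the limit leaves the size open) is expected to stay within the scatter.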

Compound 4, half-maximal inhibitory concentration: 45100 nM
The estimate for compound 4 lay 2.2-fold (0.35 log units) above the measured number; the measured number falls inside the stated range.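

Going by these compounds alone, at the amide-type nitrogen, phenyl gives the first readable change at this position: in this assay there is an at least 2.2-fold lower number from compound 3 to compound 4 (0.34 log units; beyond the scatter), with phenyl replacing 4-methylbenzyl, and an at least 2.2-fold lower number from compound 1 to compound 4 (0.34 log units; beyond the scatter), with phenyl replacing propyl. The group on this nitrogen therefore moves the number, and the anilino compound 4 stands lower than both compound 1 and compound 3. Both steps give only a lower bound on size because compound 1 and compound 3 each sit at a limit of the assay: the limit of > 100000 nM in this assay, at which 2 of the 4 values shown sit.

As far as these compounds go, how large these steps really are remains open, as does whether the methoxy step seen with the 4-methylbenzyl amide carries over to the anilino amide. Also open, from the compounds shown here alone, is how a plain benzyl on this nitrogen, or a chlorine or carboxylic acid on the phenyl ring, would read.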